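A methoxy step from the lowest of three compounds

This account rests on a few compounds, and the source may have more. Where it says the series, first, only, none or still open, it means among the compounds named here.

Compound 1 `COc1cc(/C=C/C(=O)/C=C/c2cccs2)ccc1OCc1cn(CCOc2cc(=O)oc3ccccc23)nn1` gives 66%
Compound 2 `COc1cc(/C=C/C(=O)/C=C/c2ccccc2)ccc1OCc1cn(CCCCOc2cc(=O)oc3ccccc23)nn1` gives 31%
Compound 3 `COc1cc(/C=C/C(=O)/C=C/c2cc(OC)c(OC)c(OC)c2)ccc1OCc1cn(CCCCCOc2cc(=O)oc3ccccc23)nn1` gives 51%

In a functional assay on COLO 205 cells (Homo sapiens) for inhibition, read by sulforhodamine B assay, with a stated time of 48 h, tested at 50 uM (a higher number here means more inhibition of growth at the concentration tested, a lower number less inhibition of growth), compound 2 stands lowest at 31% among these three compounds. Compound 4 `COc1ccc(/C=C/C(=O)/C=C/c2ccc(OCc3cn(CCCCOc4cc(=O)oc5ccccc45)nn3)c(OC)c2)cc1` is still unmeasured. It differs from compound 2 by methoxy in place of hydrogen on an aromatic carbon in one place: methoxy in place of hydrogen on an aromatic carbon, which turns phenyl into 4-methoxyphenyl. Among the measured compounds shown here, no measured pair differs in one place only, so the guide is thin. Compound 3 at 51% and compound 1 at 66% both sit beyond the scatter above compound 2, so a small rise in this assay is expected, perhaps none beyond the scatter. The estimated change is a number 7 percentage points higher from compound 2 to compound 4 (within the scatter) in growth inhibition. For compound 4 the estimate is 38% within an expected range of 20% to 58% in this measurement.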

Compound 4, percent growth inhibition at one concentration: 49%
Beside the measured number, compound 4's estimate is 11 percentage points below it; measured number inside the range.
By their numbers in this assay, from the lowest: compound 2; then compounds 4 and 3 (each within the scatter of the next); then compound 1.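

In this assay, among the compounds shown here, the only comparison here that changes one place gives a number 18 percentage points higher from compound 2 to compound 4 (beyond the scatter) and so ties a rise beyond the scatter to the swap of phenyl for 4-methoxyphenyl, with the rest of the molecule unchanged. The earlier compounds shown here differed in several places at once, so none of them could isolate this position. Nothing available explains why this rise occurs. Still open, going by these compounds, is whether a hydroxyl group, a chlorine atom or an amine at this same place would raise growth inhibition too. On these data alone, whether the methoxy step holds with a shorter or longer chain also remains unknown.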